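The source may hold more compounds than are shown below. What is called first, only, known or untested is meant among the compounds shown, and "the series" means these compounds.

Compound 2 `CS(=O)(=O)NC(=O)c1ccc(Nc2nc(NC3(c4ccc(Cl)cc4)CC3)nc(OCC(F)(F)F)n2)cc1`: 11 nm/s
Compound 1 `CNC(=O)NCCS(=O)(=O)NC(=O)c1ccc(Nc2nc(NC3(c4ccc(Cl)cc4)CC3)nc(OCC(F)(F)F)n2)cc1`: 40 nm/s

In a physicochemical assay for permeability, using PAMPA, at pH 7.4 (a higher number here means that the compound crosses the layer faster, a lower number that the compound crosses the layer more slowly), compound 2 gives 11 nm/s, the lowest of the two numbers recorded so far; compound 1 gives 40 nm/s. Compound 3 `COC(=O)NCCS(=O)(=O)NC(=O)c1ccc(Nc2nc(NC3(c4ccc(Cl)cc4)CC3)nc(OCC(F)(F)F)n2)cc1` differs from compound 2 in one place: ((methoxycarbonyl)amino)methyl in place of hydrogen on a saturated chain carbon bound to a sulfonyl sulfur. Among the compounds with values here, the only measured step that bears on this change is a 3.6-fold lower number from compound 1 to compound 2 (0.56 log units; beyond the scatter), which shows that a closely related group at the same place went with a higher number when present. The new group resembles that one in size and in its donor and acceptor count, so a step of similar direction and size is expected. Compound 3 is therefore expected to give about 35 nm/s, with a likely range from 15 nm/s to 80 nm/s. The expected step is a 3.2-fold higher number from compound 2 to compound 3 (0.50 log units; beyond the scatter), a modest rise comparable to the one already seen.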

Compound 3, apparent permeability: 39 nm/s
Compound 3: the middle estimate sits 1.1-fold (0.05 log units) below what was measured; measured number inside the range.
By their numbers in this assay, from the lowest: compound 2; then compounds 3 and 1 (each within the scatter of the next).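

In this assay, ((methoxycarbonyl)amino)methyl in place of hydrogen gives a 3.5-fold higher number from compound 2 to compound 3 (0.55 log units; beyond the scatter). Within the data shown here, a rise at this saturated chain carbon bound to a sulfonyl sulfur is therefore no longer tied to the single group in compound 1, since a second group now shows it as well. Methoxy in place of methylamino on the carbonyl carbon gives a 1.0-fold lower number from compound 1 to compound 3 (0.01 log units; within the scatter), so this exchange at the end of the chain leaves no readable difference, and nothing measured here explains that likeness.

Still open is how much of the added group the rise requires: would a plain ethyl group, a free amine or a carboxylic acid on the sulfonyl sulfur give the same result? A longer chain ending in the same carbamate also remains an open case.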